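Aryl versus ethyl on the ring nitrogen of a thiazolidinone

The source may hold more compounds than are shown below. What is called first, only, known or untested is meant among the compounds shown, and "the series" means these compounds.

Measured so far:
Compound 1, `COc1ccc(F)cc1N1C(=O)CSC1c1cccc(C(=O)NCCCCc2ccccc2)c1`: 76%
Compound 2, `CCN1C(=O)CSC1c1cccc(C(=O)NCCCCc2ccccc2)c1`: 3%

In a functional assay on SJSA-1 cells (Homo sapiens) for inhibition, read by CCK-8 assay, with a stated time of 72 h, tested at 1 uM (a lower number here means less inhibition, a higher number more inhibition at the concentration tested (going by the name of the read-out)), compound 2 stands lowest of the two numbers shown; its nearest neighbour is compound 1, which lies a long way higher. Within the data shown here, the only step between measured compounds is a number 73 percentage points lower from compound 1 to compound 2 (beyond the scatter), which replaces 5-fluoro-2-methoxyphenyl on the ring nitrogen by ethyl and removes nearly all inhibition.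

Compound 3, `COc1cc(F)ccc1N1C(=O)CSC1c1cccc(C(=O)NCCCCc2ccccc2)c1`, reverses that kind of change: 4-fluoro-2-methoxyphenyl in place of ethyl on an amide-type nitrogen in a ring. Among the measured compounds shown here, the entering group, 4-fluoro-2-methoxyphenyl, is a near relative of the 5-fluoro-2-methoxyphenyl group of compound 1, so the one relevant step, which was large, argues for a large gain in this assay. The step of a number 62 percentage points higher from compound 2 to compound 3 (beyond the scatter) is therefore expected to be strongly upward, roughly mirroring the loss seen earlier. Compound 3 is estimated at 65%, with a range from 35% to 90%.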

Compound 3, a percentage reported as inhibition, at one concentration (the size of the read-out at that concentration, not a potency): 77%
Beside the measured number, compound 3's estimate is 12 percentage points below it, within the range that was stated.
By their numbers in this assay, from the lowest: compound 2; then compounds 1 and 3 (each within the scatter of the next).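

In this assay, among these compounds, there is a number 74 percentage points higher from compound 2 to compound 3 (beyond the scatter), so the large difference between ethyl and an aryl group on this amide-type nitrogen now appears with two different aryl groups, not just the one in compound 1. Moving the fluorine changes little, with a number 1 percentage points higher from compound 1 to compound 3 (within the scatter), so the 5-fluoro-2-methoxyphenyl and 4-fluoro-2-methoxyphenyl groups cannot be told apart at this concentration. Nothing in the data shown gives a reason for these numbers.

On these data alone, both aryl groups carry fluoro and methoxy substituents, so it remains open whether either one matters, and plain phenyl or 2-methoxyphenyl would test that. As far as these compounds go, it is also open whether an aromatic ring is needed at all, or whether cyclohexyl, benzyl or a longer chain such as hexyl would serve in place of ethyl.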